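From a Hydroxy Chain to a Carboxymethyl Chain

The source may report more compounds than this note shows. Statements on the series, on what has been measured and on what is new or still open speak of the compounds shown alone.

For the measured compounds named here, compound 3 `COc1cccc(Sc2c(NS(=O)(=O)c3ccc(C(C)(C)C)cc3)noc2CCO)c1` gives 430 nM in an assay on COS-7 cells for displacement of a labelled ligand from Endothelin receptor type B (Sus scrofa) (on this read-out lower numbers stand for stronger inhibition and higher numbers for weaker inhibition), the highest of the three numbers so far. Compound 1 `COC(=O)CCCc1onc(NS(=O)(=O)c2ccc(C(C)(C)C)cc2)c1Sc1cccc(OC)c1` gives 310 nM, and compound 2 `COc1cccc(Sc2c(NS(=O)(=O)c3ccc(C(C)(C)C)cc3)noc2CCC/C=N/O)c1` gives 85 nM. One step, a 1.4-fold higher number from compound 1 to compound 3 (0.14 log units; within the scatter), lies within the scatter; the other, a 5.1-fold higher number from compound 2 to compound 3 (0.70 log units; beyond the scatter), lies beyond it. Compound 4 `COc1cccc(Sc2c(NS(=O)(=O)c3ccc(C(C)(C)C)cc3)noc2CCCC(=O)O)c1` differs from compound 3 by carboxymethyl in place of hydroxy on a saturated chain carbon, two bonds along the chain from an aromatic carbon. Going by the values given here, the closest precedent is compound 1, whose chain ends in a methyl ester and whose step a 1.4-fold higher number from compound 1 to compound 3 (0.14 log units; within the scatter) stayed within the scatter, while only compound 2 moved the number clearly. A modest step toward a lower number is therefore expected, estimated as a 2.9-fold lower number from compound 3 to compound 4 (0.46 log units; beyond the scatter). Compound 4 is expected to give 150 nM, with a range from 40 nM to 500 nM.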

Compound 4, half-maximal inhibitory concentration: 500 nM
Estimate against measurement, compound 4: 3.3-fold (0.52 log units) below, and the stated range covers the measured number.
By their numbers in this assay, from the lowest: compound 2; then compounds 1, 3 and 4 (each within the scatter of the next).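

Placing carboxymethyl in place of hydroxy, on a saturated chain carbon two bonds along the chain from an aromatic carbon, hardly shifts the result in this assay (a 1.2-fold higher number from compound 3 to compound 4 (0.07 log units; within the scatter)). Hydrogen in place of methyl on the oxygen next to the carbonyl group likewise stays within the scatter (a 1.6-fold higher number from compound 1 to compound 4 (0.21 log units; within the scatter)), while the chain of compound 2 remains clearly apart (a 5.9-fold higher number from compound 2 to compound 4 (0.77 log units; beyond the scatter)). Nothing available explains these results. The compounds shown leave open whether a chain ending in an amine or an amide would match compound 2. They also leave open how a longer chain bearing the carboxylic acid would compare.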